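Ester from the bromomethyl intermediate on the shared core

The source may report more compounds than this note shows. Statements on the series, on what has been measured and on what is new or still open speak of the compounds shown alone.

Compound 1 `CCc1cccc2c(OC)c(-c3occ(C)c3C(=O)NC)ccc12` carries methylcarbamoyl on an aromatic carbon. In a functional assay on KB cells (Homo sapiens) for cytotoxicity, read by MTT assay, with a stated time of 72 h (on this read-out lower numbers stand for an effect already at smaller amounts and higher numbers for an effect only at larger amounts of compound), compound 1 gives only the limit > 10 ug/mL. Compound 2 `CCc1cccc2c(OC)c(-c3occ(C)c3CBr)ccc12` has bromomethyl in place of methylcarbamoyl. In this assay compound 2 likewise gives only the limit > 10 ug/mL. The step that the two limits leave unreadable from compound 1 to compound 2 is therefore not readable, as the limit of > 10 ug/mL in this assay, at which 2 of the 2 values shown sit, holds both values shown so far. Compound 3 `CCc1cccc2c(OC)c(-c3occ(C)c3COC(=O)CCN(CC)CC)ccc12` differs from compound 2 by ((2-(diethylamino)ethyl)carbonyl)oxy in place of bromo on a saturated chain carbon bound to an aromatic carbon. Within the data shown here, no measured step bears on this change: the only step between measured compounds sits at a limit on both sides, so neither a direction nor a size can be drawn from it for this assay. For compound 3 the expected outcome is a value near the limit again, estimated at 8 ug/mL within 2 ug/mL to 30 ug/mL. The estimated step of an at least 1.2-fold lower number from compound 2 to compound 3 (0.09 log units; that floor lies within the scatter) thus rests on no readable anchor and is expected to stay within the scatter.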

Compound 3, concentration for half-maximal effect: > 10 ug/mL
Compound 3: no number, only a limit (the forecaster's own chance of this, stated with the estimate: 55%); middle value at least 1.2-fold (0.09 log units) away from the limit.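

In this assay, among these compounds, compound 3 gives > 10 ug/mL as a limit only, so no step from compound 2 to compound 3 can be read: the limit of > 10 ug/mL in this assay, at which 3 of the 3 values shown sit. The compounds shown leave open whether any change on the shared core yields an actual number on this read-out.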